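Replacing phenyl on an amide-type nitrogen

A few compounds are considered here, and "the series" means these few. Any claim that something is new, unique, unknown or untested is made for them only; others in the source may bear on it.

Compound 1 `CC(=O)NCc1csc(NC(=O)c2cc(C(C)(C)C)nn2Cc2ccccc2)n1` gives 12.5 ug/mL in the test below
Compound 2 `CC(C)(C)c1cc(C(=O)Nc2ccccc2)n(Cc2ccccc2)n1` gives 1.6 ug/mL in the same test

In a physicochemical assay for solubility, read by nephelometry, measured as kinetic solubility, at pH 2.0 (a higher number here means a more soluble compound, a lower number a less soluble compound), compound 2 stands lowest of the two numbers at 1.6 ug/mL and compound 1 lies higher at 12.5 ug/mL with a gap beyond the usual scatter. Compound 3 `Cc1csc(NC(=O)c2cc(C(C)(C)C)nn2Cc2ccccc2)n1` has not yet been measured. It differs from compound 2 by a single change, 4-methyl-1,3-thiazol-2-yl in place of phenyl on an amide-type nitrogen. Going by the values given here, no measured pair of compounds shows this change alone, so any expectation rests on thin evidence. Compound 1 gives 12.5 ug/mL with a five-membered aromatic ring on an amide-type nitrogen, and on that ground alone a rise in this assay is expected for compound 3. The expected step is a 2.8-fold higher number from compound 2 to compound 3 (0.45 log units; beyond the scatter) in the upward direction, moderate in size but beyond the scatter. Compound 3 is estimated at 4.5 ug/mL (expected range 1.8 ug/mL to 11 ug/mL).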

Compound 3, solubility: < 1.6 ug/mL
Compound 3: a limit, no number; the forecaster's own chance of this, stated with the estimate: 10%; middle value at least 2.8-fold (0.44 log units) from the limit.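

In this assay compound 3 reads < 1.6 ug/mL, which is a limit of the assay and not a number. Putting 4-methyl-1,3-thiazol-2-yl in place of phenyl on an amide-type nitrogen therefore gives a number no higher from compound 2 to compound 3 (the limit leaves the size open) though the size of that step cannot be read, and the five-membered aromatic ring seen in compound 1 does not by itself bring a rise at this position. The comparison that can be read is a different one: hydrogen in place of acetamido on a saturated chain carbon bound to an aromatic carbon gives an at least 7.8-fold lower number from compound 1 to compound 3 (0.89 log units; beyond the scatter), so in this pair the higher number is found only with the acetamido group present, and the reading of compound 3 rests on this limit: the limit of < 1.6 ug/mL in this assay, at which 1 of the 3 values shown sits.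

Going by these compounds, what stays open is how far compound 3 truly lies under that limit, and so whether the ring change lowers the number at all. Also open, on these data alone, is whether an amine or a carboxylic acid in place of acetamido on that chain carbon would give a higher number in this assay than acetamido does.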